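Swapping the Alkynyl Side Chain on a Nucleoside Analogue

The compounds below may be only part of what the source reports. "The series", "measured", "known", "first", "only" and "open" are said of these compounds alone.

Of the compounds shown here, three have been tested in an ADME assay on L1210/0 cells (Mus musculus) for cytotoxicity, with a stated time of 48 h (a lower number here means a stronger inhibitor, a higher number a weaker inhibitor), and none of them gave a number. Compound 1, `C[C@H](O)C1CC(Cn2cnc3c(N)ncnc32)C1(C)C`, reached only the limit of > 200000 nM in this assay. Compound 2, `O=c1[nH]c(=O)n([C@@H]2CCC[C@H]2CO)cc1I`, likewise stopped at the limit of > 200000 nM. Compound 3, `COCC#Cc1cn([C@H]2C[C@H](O)[C@@H](CO)O2)c(=O)[nH]c1=O`, also returned only the limit of > 200000 nM. Compound 3 therefore stands nowhere in particular on the numbers shown: all three values are limits, as summarised by the limit of > 200000 nM in this assay, at which 3 of the 3 values shown sit, and no step between measured compounds can be drawn.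

The next compound in line is compound 4, `C#COc1cn([C@H]2C[C@H](O)[C@@H](CO)O2)c(=O)[nH]c1=O`. It differs from compound 3 in one place: ethynyloxy in place of 3-methoxyprop-1-yn-1-yl on an aromatic carbon. Both the group that leaves and the group that enters carry a triple bond outside aromatic rings and one hydrogen-bond acceptor, and the change sits on the same aromatic carbon.

With every measured value resting at the limit, there is no basis for expecting this change to move compound 4 off it, so the expected step of a number no higher from compound 3 to compound 4 (the limit leaves the size open) is none beyond the scatter. Compound 4 is accordingly estimated to give 200000 nM in this assay, within a range from 60000 nM to 600000 nM, most likely reported again as a limit.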

Compound 4, half-maximal inhibitory concentration: > 200000 nM
Compound 4: only a limit was reported; the forecaster's own chance of this, stated with the estimate: 85%; the middle value sits exactly at the limit.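

Compound 3 and compound 4 both gave only a limit, so no step can be read between them in this assay: the limit of > 200000 nM in this assay, at which 4 of the 4 values shown sit.

The compounds shown leave open how ethynyloxy and 3-methoxyprop-1-yn-1-yl compare on the shared core in this assay, and whether any change to that core would yield a number rather than a limit.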